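The source may hold more compounds than are shown below. What is called first, only, known or untested is meant among the compounds shown, and "the series" means these compounds.

In an assay for inhibition of solute carrier family 22 member 12 (Homo sapiens), read by scintillation counting, with a stated time of 60 min, tested at 50 uM (on this read-out higher numbers stand for more inhibition at the one concentration tested (going by the name of the read-out) and lower numbers for less inhibition), compound 1 `CCc1oc2ccc(OC)cc2c1C(=O)c1ccc(OC)cc1` gives 24.3%. Compound 3 `CCc1oc2ccc(O)cc2c1C(=O)c1ccc(OC)cc1` carries the change (hydrogen in place of methyl on an oxygen on an aromatic ring), and in this assay compound 3 gives 12.9%, so the step is a number 11.4 percentage points lower from compound 1 to compound 3 (beyond the scatter). Compound 2 `CCc1cc2c(C(=O)c3ccc(OC)cc3)c(OC)ccc2o1` has the same atoms as compound 1 joined differently; the difference between the two cores is not broken down here. In this assay compound 2 gives 6.1%, within the scatter of compound 3 and beyond it from compound 1. Compound 4 `CCc1cc2c(C(=O)c3ccc(O)cc3)c(OC)ccc2o1` is made from compound 2 by the same change, (hydrogen in place of methyl on an oxygen on an aromatic ring), which occurs twice among the compounds shown. Because the earlier step was a number 11.4 percentage points lower from compound 1 to compound 3 (beyond the scatter), the step from compound 2 to compound 4 is expected to be a number 4.1 percentage points lower from compound 2 to compound 4 (within the scatter), smaller only since compound 2 already reads low. Compound 4 is thus estimated at 2%, between -6% and 12%.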

Compound 4, a percentage reported as inhibition, at one concentration (the size of the read-out at that concentration, not a potency): 88.2%
For compound 4 the middle estimate is 86.2 percentage points below the measured one; measured number outside the range, above it.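

In this assay, methoxy to hydroxy gave a number 82.1 percentage points higher from compound 2 to compound 4 (beyond the scatter), so the step seen on one core did not carry over to the other, and the two steps point in opposite directions: the same change on two cores in this assay, a number 11.4 percentage points lower (beyond the scatter) from compound 1 to compound 3 and a number 82.1 percentage points higher (beyond the scatter) from compound 2 to compound 4, 93.5 percentage points apart, beyond the scatter of two such steps. In this series, then, the outcome of this change on one core gives no safe estimate of its outcome on the other. Among the compounds shown here, the comparison does not show what lies behind the gap, and with only one pair on each core it offers no rule for any further core.

The compounds shown leave open whether an amine or a carboxylic acid in place of the hydroxy of compound 4 would keep its high reading. They also leave open how a longer chain on the core of compound 4 would read.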